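Swapping one ring for another on a shared aryl sulfonyl core

This account rests on a few compounds, and the source may have more. Where it says the series, first, only, none or still open, it means among the compounds named here.

Of the compounds shown here, three built on one core have been tested in a functional assay on HeLa cells (Homo sapiens) for antiproliferative activity, read by MTT assay, with a stated time of 72 h; on this read-out higher numbers stand for weaker inhibition and lower numbers for stronger inhibition. Compound 1 `Cc1cc(S(=O)(=O)/N=C(\N)N/N=C/C#Cc2ccccc2)c(SCc2ccccc2Cl)cc1Cl` gives 14000 nM. Compound 2 `C/C(C#Cc1ccccc1)=N\N/C(N)=N/S(=O)(=O)c1cc(C)c(Cl)cc1SCc1ccccc1Cl` gives 25000 nM. Compound 3 `Cc1cc(S(=O)(=O)/N=C(\N)N/N=C/C#Cc2ccccc2)c(SCc2cccc3ccccc23)cc1Cl` gives 8000 nM.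

Compound 1 and compound 2 differ in one place: a group of 11 heavy atoms (10 carbon, 1 nitrogen; one six-membered aromatic ring of carbon only) in place of a group of 10 heavy atoms (9 carbon, 1 nitrogen; one six-membered aromatic ring of carbon only), on an amine nitrogen. This change produced a 1.8-fold higher number from compound 1 to compound 2 (0.25 log units; within the scatter). Compound 1 and compound 3 differ in the group attached to the sulfur: naphthalen-1-yl in place of 2-chlorophenyl on a saturated chain carbon bound to a sulfur, a change that gave a 1.8-fold lower number from compound 1 to compound 3 (0.24 log units; within the scatter).

Compound 4 `C/C(C#Cc1ccccc1)=N\N/C(N)=N/S(=O)(=O)c1cc(C)c(Cl)cc1SCc1cccc2ccccc12` has not yet been measured. It stands to compound 3 as compound 2 stands to compound 1: a group of 11 heavy atoms (10 carbon, 1 nitrogen; one six-membered aromatic ring of carbon only) in place of a group of 10 heavy atoms (9 carbon, 1 nitrogen; one six-membered aromatic ring of carbon only), on an amine nitrogen. The place of the change is described in the same words in both pairs, so the change is the same one, made on a different core.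

Among the compounds with values here, the only guide is the one measured step. Since the change from compound 1 to compound 2 gave a 1.8-fold higher number from compound 1 to compound 2 (0.25 log units; within the scatter), a step of similar size is expected from compound 3 to compound 4, estimated as a 1.8-fold higher number from compound 3 to compound 4 (0.24 log units; within the scatter). Compound 4 is therefore expected to give about 14000 nM in this assay, with an estimated range from 6000 nM to 35000 nM. Whether a change made on one core carries over to another core is uncertain here, and the range is set wide for that reason.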

Compound 4, half-maximal inhibitory concentration: 125000 nM
For compound 4 the middle estimate is 8.9-fold (0.95 log units) below the measured one, outside the stated range (above it).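

Placed on the core of compound 3, the group of 11 heavy atoms on the amine nitrogen gave a 16-fold higher number from compound 3 to compound 4 (1.19 log units; beyond the scatter), so in this assay the size of this step did not carry over from the core of compound 1: the same change on two cores in this assay, a 1.8-fold higher number (0.25 log units; within the scatter) from compound 1 to compound 2 and a 16-fold higher number (1.19 log units; beyond the scatter) from compound 3 to compound 4, 8.8-fold (0.94 log units) apart, beyond the scatter of two such steps. Seen from the other side of the same four compounds, naphthalen-1-yl in place of 2-chlorophenyl gave a 5.0-fold higher number from compound 2 to compound 4 (0.70 log units; beyond the scatter) when the group of 11 heavy atoms was present, so the two changes do not simply add up: the same change on two cores in this assay, a 1.8-fold lower number (0.24 log units; within the scatter) from compound 1 to compound 3 and a 5.0-fold higher number (0.70 log units; beyond the scatter) from compound 2 to compound 4, 8.8-fold (0.94 log units) apart, beyond the scatter of two such steps. This does not show why the two changes interact, and it rests on a single set of four compounds, so it gives no rule for how far the step would change on any other core in the series.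

Going by these compounds, it remains open whether a phenyl group without the chlorine on the saturated chain carbon bound to the sulfur would behave like 2-chlorophenyl or like naphthalen-1-yl when the group of 11 heavy atoms is present. Also open, on these data alone, is whether a longer chain within the group on the amine nitrogen would raise the number further on either core.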